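Methyl to acetyl on the ring nitrogen: compound 3

The source may hold more compounds than are shown below. What is called first, only, known or untested is meant among the compounds shown, and "the series" means these compounds.

Measured in a functional assay on MGC-803 cells (Homo sapiens) for inhibition, read by CCK-8 assay, with a stated time of 48 h; a lower number here means a stronger inhibitor, a higher number a weaker inhibitor:
- compound 1 `COc1ccc(CN(C(=O)CSC(=S)N2CCN(C(C)=O)CC2)c2cc(OC)c(OC)c(OC)c2)cc1`: 480 nM
- compound 2 `COc1ccc(CN(C(=O)CSC(=S)N2CCN(C)CC2)c2cc(OC)c(OC)c(OC)c2)cc1O`: 860 nM

Compound 2, at 860 nM, lies within the scatter of compound 1, at 480 nM, so these two values do not separate and give no ranking. Within the data shown here, no two measured compounds differ in only one place, so no measured step speaks directly to the change considered here.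

Compound 3 `COc1ccc(CN(C(=O)CSC(=S)N2CCN(C(C)=O)CC2)c2cc(OC)c(OC)c(OC)c2)cc1O` follows from compound 2 with acetyl in place of methyl on an amine nitrogen in a ring. The same 4-acetylpiperazin-1-yl group is present in compound 1, which gives 480 nM, so the acetyl group is not expected to bring a loss. In this assay a small step towards a lower number is expected, none beyond the scatter. The estimated change is a 1.6-fold lower number from compound 2 to compound 3 (0.19 log units; within the scatter), and this rests on very little data. For compound 3 the expected value is 550 nM, with an estimated range of 220 nM to 1300 nM.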

Compound 3, half-maximal inhibitory concentration: 310 nM
Estimate against measurement, compound 3: 1.8-fold (0.25 log units) above; measured number inside the range.
By their numbers in this assay, from the lowest: compounds 3, 1 and 2 (each within the scatter of the next, the first and the last beyond it).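

In this assay, among these compounds, the change from 4-methylpiperazin-1-yl to 4-acetylpiperazin-1-yl gives a 2.8-fold lower number from compound 2 to compound 3 (0.44 log units; beyond the scatter), the first single-place reading on this ring nitrogen, and it shows that with the hydroxy group held constant, acetyl gives the lower number. The second single-place pair, hydroxy in place of hydrogen on an aromatic carbon, gives a 1.5-fold lower number from compound 1 to compound 3 (0.19 log units; within the scatter), so with acetyl on the ring nitrogen the hydroxy group does not separate these two compounds. The data offer no measurement that would explain either step.

The compounds shown leave open whether a longer acyl chain, a carbamate or an unsubstituted ring amine on this nitrogen would move the number further from that of the methyl compound, and so whether the step is particular to acetyl. They also leave open whether methyl to acetyl gives a step of the same size without the hydroxy group, and what a methoxy group or a fluorine on that aromatic carbon would give in place of hydroxy.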